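Swapping the Ring on the Thiocarbonyl Carbon

This account rests on a few compounds, and the source may have more. Where it says the series, first, only, none or still open, it means among the compounds named here.

Compound 3 `O=c1c(Cl)c(CSC(=S)N2CCCCC2)oc2ccccc12` gives 3300 nM in a functional assay on LM7 cells (Homo sapiens) for antiproliferative activity, read by MTT assay, with a stated time of 72 h (a higher number here means a weaker inhibitor, a lower number a stronger inhibitor), the lowest of the two numbers recorded so far. Compound 2 `O=c1c(CSC(=S)N2CCCC2)coc2ccccc12` gives 6000 nM in this assay, which lies within the scatter of compound 3. For compound 1 `O=c1cc(CSC(=S)N2CCCCC2)oc2ccccc12` only a limit is known, > 25000 nM in this assay. For the measured compounds named here, the one measured step, an at least 7.5-fold lower number from compound 1 to compound 3 (0.87 log units; beyond the scatter), concerns chloro in place of hydrogen on an aromatic carbon and not the ring on the thiocarbonyl carbon. Compound 4 `O=c1c(Cl)c(CSC(=S)N2CCCC2)oc2ccccc12` differs from compound 3 by pyrrolidin-1-yl in place of piperidin-1-yl on a thiocarbonyl carbon. Going by the values given here, no measured step covers this change; compound 2 carries the same pyrrolidin-1-yl ring but differs from compound 3 in other places as well. The step of a 1.1-fold higher number from compound 3 to compound 4 (0.03 log units; within the scatter) is therefore expected to stay within the scatter. Compound 4 is estimated at 3500 nM, with a range from 1500 nM to 9000 nM.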

Compound 4, half-maximal inhibitory concentration: 1900 nM
Compound 4: middle estimate off by 1.8-fold (0.27 log units), on the high side, and the stated range covers the measured number.
By their numbers in this assay, from the lowest: compounds 4, 3 and 2 (each within the scatter of the next, the first and the last beyond it). At a limit, above all of these: compound 1.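

This is the only pair shown in which the ring on the thiocarbonyl carbon changes while the rest of the molecule stays the same: in this assay, pyrrolidin-1-yl in place of piperidin-1-yl gives a 1.7-fold lower number from compound 3 to compound 4 (0.24 log units; within the scatter). With the chloro group present, this position accepts either ring, and the two cannot be told apart. No measurement shown gives a reason for this result. Open, on these data alone, is whether a morpholine ring or an open-chain diethylamine on the thiocarbonyl carbon would give a similar number, and whether the ring swap reads the same with hydrogen in place of chloro.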